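Ethoxy to 4-aminophenoxy on the shared core

The compounds below may be only part of what the source reports. "The series", "measured", "known", "first", "only" and "open" are said of these compounds alone.

In a functional assay on HMEC-1 cells (Homo sapiens) for antiproliferative activity, read by cell counting, with a stated time of 4 days (a higher number here means a weaker inhibitor, a lower number a stronger inhibitor), compound 1 `CC(Nc1ccccc1Oc1ccc(Cl)cc1)=C1C(=O)CC(c2ccccc2)CC1=O` gives 260 nM, compound 2 `CC(Nc1ccccc1Oc1ccc(C(C)O)cc1)=C1C(=O)CC(c2ccccc2)CC1=O` gives 140 nM and compound 3 `CCOc1ccccc1NC(C)=C1C(=O)CC(c2ccccc2)CC1=O` gives 100 nM. Compound 3 stands apart from compound 1 only, and by a modest margin. Compound 4 `CC(Nc1ccccc1Oc1ccc(N)cc1)=C1C(=O)CC(c2ccccc2)CC1=O` has 4-aminophenyl in place of ethyl on an oxygen on an aromatic ring. The closest evidence runs the opposite way, with ethyl replacing 4-chlorophenyl in a 2.6-fold lower number from compound 1 to compound 3 (0.41 log units; beyond the scatter) and ethyl replacing 4-(1-hydroxyethyl)phenyl in a 1.4-fold lower number from compound 2 to compound 3 (0.15 log units; within the scatter). Swapping the group on that phenyl gave a 1.9-fold lower number from compound 1 to compound 2 (0.27 log units; within the scatter). A small move to a higher number is therefore expected in this assay. The expected size is a 1.8-fold higher number from compound 3 to compound 4 (0.26 log units; within the scatter). The estimate for compound 4 is 180 nM, within a range of 70 nM to 450 nM.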

Compound 4, half-maximal inhibitory concentration: 47 nM
The estimate for compound 4 lay 3.8-fold (0.58 log units) above the measured number; measured number outside the range, below it.
By their numbers in this assay, from the lowest: compound 4; then compounds 3, 2 and 1 (each within the scatter of the next, the first and the last beyond it).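

In this assay no substituted phenyl on this oxygen had yet gone lower than ethyl, but 4-aminophenyl does: a 2.1-fold lower number from compound 3 to compound 4 (0.33 log units; beyond the scatter). The group on that phenyl now clearly counts, with amino giving a 3.0-fold lower number from compound 2 to compound 4 (0.47 log units; beyond the scatter) and a 5.5-fold lower number from compound 1 to compound 4 (0.74 log units; beyond the scatter), whereas 1-hydroxyethyl in place of chloro stayed within the scatter. No supporting measurement bears on this result.

Open, on these data alone, is whether the free amine is needed, or whether a dimethylamino or acetamido group would hold the number. As far as these compounds go, a carboxylic acid on that phenyl also remains untested within these compounds.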